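Swapping the Side Chain of Compound 1 for Isopropyl

A few compounds are considered here, and "the series" means these few. Any claim that something is new, unique, unknown or untested is made for them only; others in the source may bear on it.

Three compounds share a common core and differ in the side group on a saturated chain carbon bound to an amide-type nitrogen and a carbonyl carbon. In a functional assay on the whole organism (Tail, strain ICR) with Mus musculus as the target, in the tail flick test, with a stated time of 60 min, at a dose of 25 umol/kg by the oral route (on this read-out higher numbers stand for a stronger effect at the one dose given and lower numbers for a weaker effect), compound 1 `N=C(N)NCCC[C@H](NC(=O)CN(c1nc(Cl)nc2[nH]cnc12)C1CC1)C(=O)OCc1ccccc1` gives 30.6%; compound 2 `CC(C)[C@H](NC(=O)CN(c1ncnc2c1ncn2C1CCCCO1)C1CC1)C(=O)OCc1ccccc1` gives 34.9%; compound 3 `NC(=O)CC[C@H](NC(=O)CN(c1ncnc2c1ncn2C1CCCCO1)C1CC1)C(=O)OCc1ccccc1` gives 39.4%. Compound 1 has the lowest of the three numbers, but its gaps to compound 2 and compound 3 are both within the scatter, so no order can be claimed among them.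

Compound 4 `CC(C)[C@H](NC(=O)CN(c1nc(Cl)nc2[nH]cnc12)C1CC1)C(=O)OCc1ccccc1` has not yet been measured. Relative to compound 1 the change is a group of 3 heavy atoms (3 carbon; no ring) in place of a group of 7 heavy atoms (4 carbon, 3 nitrogen; no ring), on a saturated chain carbon bound to an amide-type nitrogen and a carbonyl carbon.

Among the compounds with values here, the one measured step that bears on this is a number 4.5 percentage points higher from compound 2 to compound 3 (within the scatter), which puts 2-carbamoylethyl in place of isopropyl on the other core and stays within the scatter. Taken in reverse, it suggests that the isopropyl group does not shift the read-out beyond the scatter. Within the data shown here, for the guanidine-bearing chain of compound 1 there is no measured step at all.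

Compound 4 is therefore expected to give about 30%, between 18% and 44%, an estimated step of a number 0.6 percentage points lower from compound 1 to compound 4 (within the scatter).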

Compound 4, a percentage reported as activity, at one dose (the size of the read-out at that dose, not a potency): 55.5%
Compound 4: middle estimate off by 25.5 percentage points, on the low side; measured number outside the range, above it.
By their numbers in this assay, from the lowest: compounds 1, 2 and 3 (each within the scatter of the next); then compound 4.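

On the core of compound 1, the side group on a saturated chain carbon bound to an amide-type nitrogen and a carbonyl carbon clearly counts in this assay: isopropyl in place of the group of 7 heavy atoms gives a number 24.9 percentage points higher from compound 1 to compound 4 (beyond the scatter). Within the data shown here, the only earlier step at this position, a number 4.5 percentage points higher from compound 2 to compound 3 (within the scatter), stayed small on the other core, but the two steps differ in their core as well as in the groups exchanged, so a small step on one core does not predict a small step on the other. Nothing measured here explains why the number rises with isopropyl.

On these data alone, it remains open whether the gain comes from the smaller group or from the removal of the nitrogen atoms. A plain butyl chain, or a chain ending in an amine or a carboxylic acid, on the core of compound 1 could help separate these two readings.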